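This account rests on a few compounds, and the source may have more. Where it says the series, first, only, none or still open, it means among the compounds named here.

Measured compounds:
compound 1, `CC(/N=c1\c(O)c(O)\c1=N/c1ccc(C#N)cc1)C(C)(C)C`, 520 nM
compound 2, `CC(C)(C)C/N=c1\c(O)c(O)\c1=N/c1ccc(C#N)cc1`, > 30000 nM
compound 3, `CCC(C)/N=c1\c(O)c(O)\c1=N/c1ccc(C#N)cc1`, 2100 nM

In a functional assay for inhibition, with Rattus norvegicus as the target (on this read-out higher numbers stand for weaker inhibition and lower numbers for stronger inhibition), compound 1 gives 520 nM. Compound 2 reaches only a limit of this assay, > 30000 nM, a value that the limit of > 30000 nM in this assay, at which 1 of the 3 values shown sits, describes. Compound 3 gives 2100 nM. The change from compound 1 to compound 2 is hydrogen in place of methyl on a saturated chain carbon bound to a double-bonded nitrogen and a saturated chain carbon, and it gave an at least 57-fold higher number from compound 1 to compound 2 (1.76 log units; beyond the scatter). The cores of compound 1 and compound 3 differ by ethyl in place of tert-butyl on a saturated chain carbon bound to a double-bonded nitrogen and a saturated chain carbon. Compound 4, `CC(C)/N=c1\c(O)c(O)\c1=N/c1ccc(C#N)cc1`, has not yet been measured; from compound 3 it is reached by hydrogen in place of methyl on a saturated chain carbon, two bonds along the chain from a double-bonded nitrogen, the same kind of change, though here the saturated chain carbon sits two bonds along the chain from the double-bonded nitrogen rather than bound to it. A smaller loss than the earlier one is expected, resting on compound 3 at 2100 nM, so compound 4 is estimated at a 3.3-fold higher number from compound 3 to compound 4 (0.52 log units; beyond the scatter). Compound 4 is thus expected to give about 7000 nM, between 2500 nM and 25000 nM.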

Compound 4, half-maximal inhibitory concentration: 13700 nM
The estimate for compound 4 lay 2.0-fold (0.29 log units) below the measured number; the measured number falls inside the stated range.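

In this assay the new step is a 6.5-fold higher number from compound 3 to compound 4 (0.81 log units; beyond the scatter), which runs the same way as the earlier step but differs from it in size: the same change on two cores in this assay, an at least 57-fold higher number (1.76 log units; beyond the scatter) from compound 1 to compound 2 and a 6.5-fold higher number (0.81 log units; beyond the scatter) from compound 3 to compound 4, at least 8.8-fold (0.94 log units) apart, beyond the scatter of two such steps. Compound 2 gives > 30000 nM, a limit of the assay. These two pairs show that the direction of this change carried over between the two cores and that its size did not, while the remaining steps are an at least 2.1-fold lower number from compound 2 to compound 4 (0.34 log units; beyond the scatter) and a 26-fold higher number from compound 1 to compound 4 (1.42 log units; beyond the scatter); they show nothing about any other core.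

On these data alone, it remains open how a cyclohexyl group or a longer chain on the double-bonded nitrogen would compare. Also open, as far as these compounds go, is what an amine or a carboxylic acid in place of the nitrile would do.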